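Urea aryl variation on the shared core

A few compounds are considered here, and "the series" means these few. Any claim that something is new, unique, unknown or untested is made for them only; others in the source may bear on it.

Compound 1 `COc1cccc(NC(=O)Nc2cccc(-c3cccc4[nH]nc(N)c34)c2)c1` gives 2490 nM in a functional assay on A549 cells (Homo sapiens) for inhibition, read by MTT assay, with a stated time of 48 h (a lower number here means a stronger inhibitor, a higher number a weaker inhibitor), the lowest of the two numbers in hand. Compound 2 `Nc1n[nH]c2cccc(-c3cccc(NC(=O)Nc4ccc(Cl)c(C(F)(F)F)c4)c3)c12` gives 3410 nM in this assay, and the two values lie within the scatter of each other. Compound 3 `Cc1ccc(NC(=O)Nc2cccc(-c3cccc4[nH]nc(N)c34)c2)cc1Cl` is not yet measured; it differs from compound 1 by 3-chloro-4-methylphenyl in place of 3-methoxyphenyl on an amide-type nitrogen. Among the measured compounds shown here, no measured pair covers this change, and the two values in hand give no ground for a step beyond the scatter. The step from compound 1 to compound 3 is therefore expected to be a 1.1-fold higher number from compound 1 to compound 3 (0.05 log units; within the scatter). Compound 3 is estimated at 2800 nM in this assay, with a range of 1200 nM to 6500 nM.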

Compound 3, half-maximal inhibitory concentration: 1750 nM
For compound 3 the middle estimate is 1.6-fold (0.20 log units) above the measured one, within the range that was stated.
By their numbers in this assay, from the lowest: compounds 3, 1 and 2 (each within the scatter of the next).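

In this assay, among the compounds shown here, the first measured pair at this position shows a 1.4-fold lower number from compound 1 to compound 3 (0.15 log units; within the scatter) for 3-chloro-4-methylphenyl in place of 3-methoxyphenyl on an amide-type nitrogen. Exchanging the methoxy oxygen for a chlorine and a methyl group on the aryl ring therefore leaves the number within the scatter. No supporting measurement bears on this step. As far as these compounds go, the separate contributions of the chlorine and the methyl group stay open, since they enter together. Also open, from the compounds shown here alone, is whether a carboxylic acid or an amine on this ring, or a cyclohexyl group in place of it, would move the number beyond the scatter.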